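Replacing the amino group of compound 3

The source may report more compounds than this note shows. Statements on the series, on what has been measured and on what is new or still open speak of the compounds shown alone.

compound 1 `CNc1cc(Oc2ccc(NC(=O)Nc3ccc(C)c(C(F)(F)F)c3)cc2)ncn1` gives > 10000 nM (a limit)
compound 2 `COc1ccc(CNc2cc(Oc3ccc(NC(=O)Nc4ccc(C)c(C(F)(F)F)c4)cc3)ncn2)cc1` gives 1000 nM
compound 3 `Cc1ccc(NC(=O)Nc2ccc(Oc3cc(N)ncn3)cc2)cc1C(F)(F)F` gives > 10000 nM (a limit)

In a functional assay on BaF3 cells (Mus musculus) for inhibition, read by CCK-8 assay, with a stated time of 72 h (on this read-out lower numbers stand for stronger inhibition of growth and higher numbers for weaker inhibition of growth), compound 3 gives > 10000 nM, which is a limit and not a number. Compound 3 thus stands at the limit of > 10000 nM in this assay, at which 2 of the 3 values shown sit.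

Compound 4 `Cc1ccc(NC(=O)Nc2ccc(Oc3cc(N(C)CCN(C)C)ncn3)cc2)cc1C(F)(F)F` has (2-(dimethylamino)ethyl)(methyl)amino in place of amino on an aromatic carbon, next to the ring nitrogen: (2-(dimethylamino)ethyl)(methyl)amino in place of amino on an aromatic carbon.

Going by the values given here, three measured steps bear on this change, as each alters a substituent on that same amino nitrogen. The clearest is an at least 10-fold lower number from compound 1 to compound 2 (1.00 log units; beyond the scatter), and its counterpart is an at least 10-fold higher number from compound 2 to compound 3 (1.00 log units; beyond the scatter). The third is a step that the two limits leave unreadable from compound 1 to compound 3, so it offers no size to work with.

Only compound 2 gives a number, 1000 nM, and its 4-methoxybenzyl group contains a ring, whereas the entering chain has no ring. The step from compound 1 to compound 2 therefore supports a move toward lower numbers only loosely, and a modest gain is the most that can be expected.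

The expected change is an at least 2.5-fold lower number from compound 3 to compound 4 (0.39 log units; beyond the scatter), toward a lower number, and a further reading at the limit remains quite possible. Compound 4 is expected at 4000 nM, with an estimated range from 600 nM to 20000 nM.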

Compound 4, concentration for 50% growth inhibition: 9410 nM
The estimate for compound 4 lay 2.4-fold (0.37 log units) below the measured number; the range from low to high includes it.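

In this assay, the steps of an at least 1.0-fold lower number from compound 3 to compound 4 (0.02 log units; that floor lies within the scatter) and an at least 1.0-fold lower number from compound 1 to compound 4 (0.02 log units; that floor lies within the scatter) both start from compounds whose values are limits and not numbers, and both floors lie within the scatter, so the (2-(dimethylamino)ethyl)(methyl)amino group gives a readable value at this position but no established gain over the smaller substituents. The ringless chain also falls well short of the (4-methoxybenzyl)amino group, with a 9.4-fold higher number from compound 2 to compound 4 (0.97 log units; beyond the scatter), so compound 2 remains the only one of the four with a value clearly separated from the others, although this comparison replaces the whole substituent and cannot assign the difference to any one part of it. Three of the four compounds therefore remain at or close to the top of the measured range, and two rest on a limit: the limit of > 10000 nM in this assay, at which 2 of the 4 values shown sit.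

As far as these compounds go, whether compound 2 owes its lower number to the benzyl ring or to the methoxy group remains open, and an unsubstituted benzylamino group at this position would separate the two. Also open, from the compounds shown here alone, is whether a ring placed at the end of a chain, as in a 2-(morpholin-4-yl)ethylamino group, would move the value toward that of compound 2.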